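The source may report more compounds than this note shows. Statements on the series, on what has been measured and on what is new or still open speak of the compounds shown alone.

Measured so far:
- Compound 1 `COc1cc(/C=C/C(=O)/C=C/c2ccco2)ccc1OCc1cn(CCCOc2cc(=O)oc3ccccc23)nn1`: 51%
- Compound 2 `COc1ccc(/C=C/C(=O)/C=C/c2ccc(OCc3cn(CCOc4cc(=O)oc5ccccc45)nn3)c(OC)c2)cc1OC`: 82%

In a functional assay on HCT-116 cells (Homo sapiens) for inhibition, read by sulforhodamine B assay, with a stated time of 48 h, tested at 50 uM (on this read-out higher numbers stand for more inhibition of growth at the one concentration tested and lower numbers for less inhibition of growth), compound 1 is the lower of the two measured compounds, and compound 2 stands above it by a gap beyond the scatter. These two compounds differ in more than one place, so their gap does not isolate the effect of any single change.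

The next compound, compound 3 `COc1cc(/C=C/C(=O)/C=C/c2ccccc2)ccc1OCc1cn(CCCOc2cc(=O)oc3ccccc23)nn1`, keeps the rest of compound 1 but has phenyl in place of furan-2-yl on a double-bonded chain carbon bound to a double-bonded chain carbon. Going by the values given here, no pair of measured compounds shows this exchange alone, so the data offer no direct guide to its size or direction. The expectation is therefore cautious: a small rise in this assay, with no step beyond the scatter. Compound 2, at 82%, shows only that a higher value is possible among these compounds.

The estimated step is a number 4 percentage points higher from compound 1 to compound 3 (within the scatter), a small rise within the scatter. For compound 3, the expected value is 55%, with an estimated range from 38% to 72%.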

Compound 3, percent growth inhibition at one concentration: 45%
Compound 3: the middle estimate sits 10 percentage points above what was measured; measured number inside the range.
By their numbers in this assay, from the lowest: compounds 3 and 1 (each within the scatter of the next); then compound 2.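

Phenyl in place of furan-2-yl on a double-bonded chain carbon bound to a double-bonded chain carbon gives a number 6 percentage points lower from compound 1 to compound 3 (within the scatter) in this assay, and this is the first comparison here that isolates a change in one place. At this position, the exchange of a five-membered aromatic ring with 1 hetero atom for a six-membered aromatic ring of carbon only, with the hydrogen-bond acceptor count going from 1 to 0, therefore leaves the growth inhibition at the one concentration tested within the usual scatter of repeated measurements. Nothing measured here offers an explanation for this result.

Going by these compounds alone, whether a dimethylamino group or a carboxylic acid placed on the phenyl of compound 3 would produce a step beyond the scatter remains open, since these two rings are the only groups compared at this position. On these data alone, compound 2 differs from compound 1 and compound 3 in more than one place, so it also remains open which of the differences of compound 2 goes with its 82%.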